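The source may hold more compounds than are shown below. What is called first, only, known or untested is meant among the compounds shown, and "the series" means these compounds.

Two compounds of this series have numbers in an assay on isolated protein for inhibition of Amine oxidase [flavin-containing] B (Homo sapiens), read by fluorescence, with stated times of 15 min and 20 min (on this read-out lower numbers stand for stronger inhibition and higher numbers for weaker inhibition), so far. Compound 1 `CC(C)(C)c1cc(CCC(=O)NCCC2CCN(Cc3ccccc3)CC2)cc(C(C)(C)C)c1O` gives 46900 nM in this assay, and compound 2 `Cc1ccc(CN2CCC(CCNC(=O)/C=C/c3cc(C(C)(C)C)c(O)c(C(C)(C)C)c3)CC2)cc1` gives 8900 nM, the lower of the two numbers, a gap beyond the scatter. Compound 3 `CC(C)(C)c1cc(/C=C/C(=O)NCCC2CCN(Cc3ccccc3Cl)CC2)cc(C(C)(C)C)c1O` carries the change (2-chlorophenyl in place of 4-methylphenyl on a saturated chain carbon bound to an amine nitrogen in a ring), a swap of one benzyl substituent for another at the same place. For the measured compounds named here, no measured pair shows a change of this kind, so the expected step of a 1.1-fold lower number from compound 2 to compound 3 (0.05 log units; within the scatter) from compound 2 is small, in either direction, and likely within the scatter. Compound 3 is estimated at 8000 nM, with a range of 3000 nM to 25000 nM.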

Compound 3, half-maximal inhibitory concentration: 9800 nM
Estimate against measurement, compound 3: 1.2-fold (0.09 log units) below; measured number inside the range.
By their numbers in this assay, from the lowest: compounds 2 and 3 (each within the scatter of the next); then compound 1.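

In this assay, 2-chlorophenyl in place of 4-methylphenyl on a saturated chain carbon bound to an amine nitrogen in a ring gives a 1.1-fold higher number from compound 2 to compound 3 (0.04 log units; within the scatter), a step within the scatter. At this position, the assay does not tell 4-methylbenzyl and 2-chlorobenzyl apart. No evidence on hand bears on this result. Still open, on these data alone, is whether a carboxylic acid or an amine on this benzyl ring would separate from these two numbers. Compound 1 differs from compound 2 and compound 3 in more than one place, so its gap cannot be assigned to a single change.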